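Diaryl aminothiophene carboxamides and an ester: compound 4

A few compounds are considered here, and "the series" means these few. Any claim that something is new, unique, unknown or untested is made for them only; others in the source may bear on it.

Measured compounds:
compound 1 `Nc1sc(-c2ccc(Cl)cc2)c(-c2ccc(Cl)cc2)c1C(=O)N1CCCCC1=O` — 4940 nM
compound 2 `Nc1sc(-c2ccc(Cl)cc2)c(-c2ccc(Cl)cc2)c1C(=O)N1CCOCC1` — 11700 nM
compound 3 `Nc1sc(-c2ccc(Cl)cc2)c(-c2ccc(Cl)cc2)c1C(=O)N1CCC(=O)CC1=O` — 9230 nM

All three share one core and differ only in the group on the carbonyl carbon. In a functional assay on PC-3 cells (Homo sapiens) for inhibition, read by sulforhodamine B assay, with a stated time of 72 h (on this read-out higher numbers stand for weaker inhibition and lower numbers for stronger inhibition), compound 1 gives 4940 nM, compound 2 gives 11700 nM and compound 3 gives 9230 nM. Compound 3 sits second highest of the three numbers; its gap to compound 2 is within the scatter, and its gap to compound 1 is also within the scatter, so no order among these can be read with confidence. For the measured compounds named here, the only step beyond the scatter is a 2.4-fold higher number from compound 1 to compound 2 (0.37 log units; beyond the scatter), a modest one; a 1.9-fold higher number from compound 1 to compound 3 (0.27 log units; within the scatter) and a 1.3-fold lower number from compound 2 to compound 3 (0.10 log units; within the scatter) stay within the scatter.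

Compound 4 `COC(=O)c1c(N)sc(-c2ccc(Cl)cc2)c1-c1ccc(Cl)cc1` is not yet measured. Its change from compound 3 is methoxy in place of 2,4-dioxopiperidin-1-yl on a carbonyl carbon. Going by the values given here, no measured step exchanges a ring for methoxy at this position, so the three amide-to-amide steps are the only guide, and they show that swapping groups on the carbonyl carbon moved this assay little. Compound 4 is therefore expected to land near the measured set, with a 1.1-fold higher number from compound 3 to compound 4 (0.03 log units; within the scatter) as the expected step, not clearly beyond the scatter. The estimate for compound 4 in this assay is 10000 nM, within a range from 3000 nM to 40000 nM.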

Compound 4, half-maximal inhibitory concentration: 2780 nM
Beside the measured number, compound 4's estimate is 3.6-fold (0.56 log units) above it; measured number below the stated range.
By their numbers in this assay, from the lowest: compounds 4, 1, 3 and 2 (each within the scatter of the next, the first and the last beyond it).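

In this assay, a ring on the carbonyl carbon turns out not to be required: methoxy, which carries no ring, gives a 3.3-fold lower number from compound 3 to compound 4 (0.52 log units; beyond the scatter) and a 4.2-fold lower number from compound 2 to compound 4 (0.62 log units; beyond the scatter). Compound 1 goes against any general advantage for methoxy, with a 1.8-fold lower number from compound 1 to compound 4 (0.25 log units; within the scatter), so the lower number holds only against the morpholin-4-yl and 2,4-dioxopiperidin-1-yl groups, while the methoxycarbonyl and (2-oxopiperidin-1-yl)carbonyl versions cannot be told apart. For the compounds shown here, the position therefore separates compound 4 from two of the three amides, and the first step of that kind between compounds 1 and 2, a 2.4-fold higher number from compound 1 to compound 2 (0.37 log units; beyond the scatter), is no longer the only one beyond the scatter.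

No measurement available here bears on what lies behind these steps. The compounds shown leave open whether the result belongs to methoxy alone or extends to a longer chain such as ethoxy, and how a carboxylic acid or an open-chain amine amide on the same carbonyl carbon would compare with compound 4 and compound 1.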